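The compounds below may be only part of what the source reports. "The series", "measured", "known", "first", "only" and "open" are said of these compounds alone.

Compound 2 `C/C(=N\NC(=O)COc1cccc2ccccc12)c1ccccc1Br` was tested in an ADME assay on HEL cells (Homo sapiens) for cytotoxicity (on this read-out lower numbers stand for higher toxicity in this test and higher numbers for lower toxicity in this test), where compound 2 gives 20 ug/mL. Compound 1 `C/C(=N\NC(=O)COc1cccc2ccccc12)c1cccc([N+](=O)[O-])c1` gives 20 ug/mL in this assay, and the step of no change at the digits printed from compound 1 to compound 2 (within the scatter) stays within the scatter, so compound 2 stands level with compound 1 on the numbers shown. Compound 3 `COc1ccc(/C=N/NC(=O)COc2cccc3ccccc23)cc1OC` gives >= 20 ug/mL in this assay, and this value is a limit of the measurement rather than a number. Among the three values, (the limit of >= 20 ug/mL in this assay, at which 1 of the 3 values shown sits). Compound 4 `C/C(=N\NC(=O)COc1cccc2ccccc12)c1ccc(O)cc1O` has not yet been measured; it differs from compound 2 in a single place: 2,4-dihydroxyphenyl in place of 2-bromophenyl on a carbon with a double bond to nitrogen. Within the data shown here, only one measured step bears on this change, the step of no change at the digits printed from compound 1 to compound 2 (within the scatter), in which one six-membered aromatic ring of carbon only replaced another on the same carbon with a double bond to nitrogen, and it brought no change beyond the scatter. Among the measured compounds shown here, the move to 2,4-dihydroxyphenyl brings in hydrogen-bond donors and acceptors that no measured step has tested, so the expectation rests on the flat behaviour seen so far. Compound 4 is therefore expected to give 20 ug/mL in this assay, with a range from 10 ug/mL to 40 ug/mL. The step of no change at the digits printed from compound 2 to compound 4 (within the scatter) is expected to remain within the scatter.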

Compound 4, minimum cytotoxic concentration: > 100 ug/mL
Compound 4 ended at the assay's limit; the forecaster's own chance of this, stated with the estimate: 40%; middle value at least 5.0-fold (0.69 log units) away from the limit.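

In this assay, the aromatic ring on the carbon with a double bond to nitrogen no longer looks like a silent position, as the replacement of 3-nitrophenyl by 2-bromophenyl had suggested: an at least 5.0-fold higher number from compound 2 to compound 4 (0.69 log units; beyond the scatter), and an at least 5.0-fold higher number from compound 1 to compound 4 (0.69 log units; beyond the scatter). Compound 4 stands at a limit of the assay and not at a number: the limit of > 100 ug/mL in this assay, at which 1 of the 4 values shown sits. Of the rings compared in these steps, only 2,4-dihydroxyphenyl carries hydrogen-bond donors, and it alone moves the read-out beyond the scatter, towards lower toxicity in this test, so what is attached to this ring can matter even though the swap between the two earlier rings changed nothing at the digits printed.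

The compounds shown leave open how far compound 4 really lies from the others, and whether both hydroxyl groups are needed or a single hydroxyl on this ring would give the same shift. They also leave open whether another group on this ring, such as an amine or a carboxylic acid, would move the read-out in the same direction.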